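Hydrogen for Chloro on the Dimethyl Trioxolane Core

This account rests on a few compounds, and the source may have more. Where it says the series, first, only, none or still open, it means among the compounds named here.

Three trioxolanes carrying a chlorinated styrene-type side chain were tested in a functional assay on HepG2 cells (Homo sapiens) for inhibition, read by MTT assay, with a stated time of 72 h; on this read-out higher numbers stand for weaker inhibition and lower numbers for stronger inhibition. Compound 1 `C=C(c1ccc(Cl)c(Cl)c1Cl)C1COC2(CCCC2)OO1` gives 8450 nM. Compound 3 `C=C(c1ccc(Cl)c(Cl)c1)C1COC2(CCCC2)OO1` shares the core of compound 1 and differs from it by hydrogen in place of chloro on an aromatic carbon; compound 3 gives 62600 nM, so that the step of a 7.4-fold higher number from compound 1 to compound 3 (0.87 log units; beyond the scatter) weakens inhibition to a degree that lies beyond the usual scatter. Compound 2 `C=C(c1ccc(Cl)c(Cl)c1Cl)C1COC(C)(C)OO1` has a different core; how the cores of compound 1 and compound 2 differ is not broken down here. In this assay compound 2 gives 27300 nM, which places it between compound 1 and compound 3.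

Compound 4 `C=C(c1ccc(Cl)cc1Cl)C1COC(C)(C)OO1` has not yet been measured. It differs from compound 2 by hydrogen in place of chloro on an aromatic carbon. Going by the values given here, this is the same kind of change as the one from compound 1 to compound 3, though its surroundings differ: in compound 4 the hydrogen enters ortho to two chloro groups and meta to a large group, whereas in compound 3 it entered ortho to a chloro group, ortho to a large group and meta to a chloro group. Among the compounds with values here, only the one earlier step, measured on a different core, is available as a guide. On that basis compound 4 is expected to show a step of about a 5.5-fold higher number from compound 2 to compound 4 (0.74 log units; beyond the scatter) in this assay, set beside the weakening seen from compound 1 to compound 3. Accordingly compound 4 is estimated at 150000 nM, with a plausible range from 50000 nM to 400000 nM, and a real chance that this assay reports only a limit.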

Compound 4, half-maximal inhibitory concentration: 90500 nM
Compound 4: middle estimate off by 1.7-fold (0.22 log units), on the high side; the measured number falls inside the stated range.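

In this assay, hydrogen in place of chloro on an aromatic carbon gives a 3.3-fold higher number from compound 2 to compound 4 (0.52 log units; beyond the scatter), so the change weakens inhibition on the core of compound 2, as it did on the core of compound 1. Set side by side, the two steps run the same way and cannot be told apart in size: the same change on two cores in this assay, a 7.4-fold higher number (0.87 log units; beyond the scatter) from compound 1 to compound 3 and a 3.3-fold higher number (0.52 log units; beyond the scatter) from compound 2 to compound 4, 2.2-fold (0.35 log units) apart, within the scatter of two such steps. Going by these compounds alone, this does not show that the step holds on every core: it rests on only two pairs, and the chloro group leaves a different place on the aromatic ring in each pair, so any influence of the core cannot be separated from that of the place.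

The compounds shown leave open how the core of compound 1 would respond to losing the chloro group that leaves compound 2, and how the core of compound 2 would respond to losing the one that leaves compound 1. They also leave open whether anything other than chloro or hydrogen on the aromatic ring, such as a fluoro group, a methoxy group or an amine, would keep or weaken inhibition on either core.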